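A few compounds are considered here, and "the series" means these few. Any claim that something is new, unique, unknown or untested is made for them only; others in the source may bear on it.

Working notes on the series. Of the compounds shown here, two have been measured in a functional assay on PC-3 cells (Homo sapiens), read by MTT assay, with a stated time of 48 h; on this read-out higher numbers stand for weaker inhibition and lower numbers for stronger inhibition. Compound 1 `CCN(CC)CCCNC(=O)c1ccc(C(CC)(CC)c2ccc(OCC(=O)C(C)(C)C)c(C)c2)n1CC` gives 1800 nM in this assay. Compound 2 `CCN(CC)CCCNC(=O)c1ccc(C(CC)(CC)c2ccc(OCC(O)C(C)(C)C)c(C)c2)n1CC` gives 2500 nM in this assay. The only measured step, a 1.4-fold higher number from compound 1 to compound 2 (0.14 log units; within the scatter), changes the chain on the aromatic oxygen, and its size means that compound 2, although it sits at the upper end of the two numbers shown, is not separated from compound 1 by this assay.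

Compound 3 `CC[C@@H](C)[C@H](NC(=O)c1ccc(C(CC)(CC)c2ccc(OCC(O)C(C)(C)C)c(C)c2)n1CC)C(=O)O` differs from compound 2 at the amide-type nitrogen: 1-carboxy-2-methylbutyl in place of 3-(diethylamino)propyl on an amide-type nitrogen. Among the measured compounds shown here, no measured step touches this part of the molecule, so the step from compound 1 to compound 2 gives no guidance for the direction or size of the change in this assay. The expectation therefore rests on the size of the exchange alone, and the step from compound 2 to compound 3 is expected to be a 1.4-fold higher number from compound 2 to compound 3 (0.15 log units; within the scatter), with a wide range. Compound 3 is estimated at 3500 nM in this assay, between 800 nM and 15000 nM.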

Compound 3, half-maximal inhibitory concentration: 1900 nM
Beside the measured number, compound 3's estimate is 1.8-fold (0.27 log units) above it; measured number inside the range.
By their numbers in this assay, from the lowest: compounds 1, 3 and 2 (each within the scatter of the next).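

In this assay, putting 1-carboxy-2-methylbutyl in place of 3-(diethylamino)propyl on the amide-type nitrogen gives a 1.3-fold lower number from compound 2 to compound 3 (0.12 log units; within the scatter), so this assay does not separate the two compounds. At this position, then, a chain ending in diethylamino and a chain bearing a carboxy group, each of 8 heavy atoms, read alike, at least with the 1-hydroxy-2,2-dimethylpropyl chain held constant on the aromatic oxygen. Nothing available explains this result.

On these data alone, it remains open whether an ester of the carboxylic acid, a primary amine or a longer chain on the amide-type nitrogen would give a step beyond the scatter. Also open, as far as these compounds go, are the effect of the other stereoisomers of 1-carboxy-2-methylbutyl and whether the exchange reads the same with (tert-butyl)carbonyl in the chain on the aromatic oxygen.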